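Sulfonyl Aryl Swap on a Weak Antiproliferative Scaffold

This account rests on a few compounds, and the source may have more. Where it says the series, first, only, none or still open, it means among the compounds named here.

Compound 1 `CC(=O)Nc1ccc(S(=O)(=O)NNC(=O)c2cccnc2Nc2ccc(Cl)cc2)cc1` is recorded in a functional assay on HOP-62 cells (Homo sapiens) for antiproliferative activity (a lower number here means a stronger inhibitor of growth, a higher number a weaker inhibitor of growth), only as a limit, where compound 1 gives > 100000 nM. That result sits at the limit of > 100000 nM in this assay, at which 1 of the 2 values shown sits, rather than at a number. Compound 2 `O=C(NNS(=O)(=O)c1ccc(F)cc1)c1cccnc1Nc1ccc(Cl)cc1Cl` gives 85100 nM in this assay. Compound 3 `O=C(NNS(=O)(=O)c1ccc(Cl)cc1Cl)c1cccnc1Nc1ccc(Cl)cc1` differs from compound 1 by 2,4-dichlorophenyl in place of 4-acetamidophenyl on a sulfonyl sulfur. Going by the values given here, no measured pair separates two aryl groups on that sulfonyl sulfur, so the estimate rests on compound 2 at 85100 nM and on what compound 1 shows. Compound 3 is expected at 70000 nM, between 20000 nM and 200000 nM. The expected step is an at least 1.4-fold lower number from compound 1 to compound 3 (0.15 log units; that floor lies within the scatter), modest and uncertain in direction.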

Compound 3, concentration for total growth inhibition: 38000 nM
Compound 3: middle estimate off by 1.8-fold (0.27 log units), on the high side, and the stated range covers the measured number.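

In this assay, the aryl group on a sulfonyl sulfur now proves able to move the result: 2,4-dichlorophenyl in place of 4-acetamidophenyl gives an at least 2.6-fold lower number from compound 1 to compound 3 (0.42 log units; beyond the scatter). Going by these compounds alone, no earlier pair had separated two aryl groups at this place. The full size of the step cannot be read because compound 1 is recorded only as a limit: the limit of > 100000 nM in this assay, at which 1 of the 3 values shown sits.

The compounds shown do not tell whether the gain belongs to the chlorine atoms or to the loss of the acetamido group. On these data alone, how an amine or a carboxylic acid on that aryl ring would read in this assay also remains open.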